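Acetyl in Place of Fluoro on a Weak Inhibitor

The compounds below may be only part of what the source reports. "The series", "measured", "known", "first", "only" and "open" are said of these compounds alone.

Measured compounds:
compound 1 `O/N=C(/Nc1cccc(F)c1)c1ccc2occc2c1`: 32700 nM
compound 2 `O/N=C(/Nc1ccc(Cl)c(F)c1)c1ccc2occc2c1`: > 30000 nM

Within the data shown here, in an assay on isolated protein for inhibition of Indoleamine 2,3-dioxygenase 1 (Homo sapiens), read by spectrophotometry (on this read-out higher numbers stand for weaker inhibition and lower numbers for stronger inhibition), compound 1 gives 32700 nM, the only number among the two values shown. Compound 2 gives > 30000 nM, which is a limit of this assay and not a number. The step that the limit leaves unreadable from compound 1 to compound 2 cannot be read because of the limit of > 30000 nM in this assay, at which 1 of the 2 values shown sits. Compound 3 `CC(=O)c1cccc(N/C(=N/O)c2ccc3occc3c2)c1` differs from compound 1 by acetyl in place of fluoro on an aromatic carbon. Among the measured compounds shown here, no measured step involves an acetyl group, so the account rests on compound 1 alone. The estimate for compound 3 is 25000 nM, between 7000 nM and 90000 nM, and the step of a 1.3-fold lower number from compound 1 to compound 3 (0.12 log units; within the scatter) is expected to stay within the scatter.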

Compound 3, half-maximal inhibitory concentration: > 30000 nM
Compound 3 gave a limit, no number; the forecaster's own chance of this, stated with the estimate: 40%; middle value at least 1.2-fold (0.07 log units) away from the limit.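

Compound 3 gives only a limit, so the step from compound 1 to compound 3 cannot be read: the limit of > 30000 nM in this assay, at which 2 of the 3 values shown sit. On these data alone, whether acetyl in place of fluoro changes inhibition at all remains open.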